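Swapping a Pyridine Ring for Cyclopentyl: Cell Tolerance

The source may report more compounds than this note shows. Statements on the series, on what has been measured and on what is new or still open speak of the compounds shown alone.

Of the compounds shown here, three have been tested in a toxicity assay on THP-1 cells (Homo sapiens) for inhibition; a lower number here means that less compound is tolerated, a higher number that more compound is tolerated. Compound 1 `COc1ccc(-c2cnc(NC(=O)c3cccnc3)n2C)cc1` reaches the ceiling of this assay: compound 1 gives > 100000 nM, which is a limit of the measurement rather than a number, as the evidence shows (the limit of > 100000 nM in this assay, at which 1 of the 3 values shown sits). Compound 2 `O=C(Nc1ncc(-c2ccccc2)o1)c1ccc(Cl)cc1` gives 10000 nM in this assay, and compound 3 `Cn1c(-c2ccccc2[N+](=O)[O-])cnc1NC(=O)c1ccc(F)cc1` gives 31000 nM. Compound 4 `COc1ccc(-c2cnc(NC(=O)C3CCCC3)n2C)cc1` differs from compound 1 in one place: cyclopentyl in place of pyridin-3-yl on a carbonyl carbon. Within the data shown here, no step between two measured compounds is available, so the effect of this change can only be estimated. Since compound 1 already sits at the limit, the step of an at least 1.4-fold lower number from compound 1 to compound 4 (0.15 log units; that floor lies within the scatter) is expected to be small or to point toward less tolerance. Compound 4 is expected to give about 70000 nM, within a range from 25000 nM to 100000 nM.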

Compound 4, half-maximal cytotoxic concentration: > 100000 nM
Compound 4: no number, only a limit; the forecaster's own chance of this, stated with the estimate: 45%; middle value at least 1.4-fold (0.15 log units) from the limit.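

Among these compounds, compound 1 and compound 4 both give only a limit, not a number, so no step between them can be read: the limit of > 100000 nM in this assay, at which 2 of the 4 values shown sit. The compounds shown leave open whether cyclopentyl in place of pyridin-3-yl on a carbonyl carbon changes the result in this assay at all.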